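A few compounds are considered here, and "the series" means these few. Any claim that something is new, unique, unknown or untested is made for them only; others in the source may bear on it.

Measured in a functional assay on RAW264.7 cells (Mus musculus) for inhibition, with stated times of 2 h and 24 h; on this read-out lower numbers stand for stronger inhibition and higher numbers for weaker inhibition:
- compound 1 `COc1ccc(/C=C2/c3cc(OC)cc(OC)c3[C@@H](c3ccc(OC)cc3)[C@@H]2c2cc(OC)cc(OC)c2)cc1`: 6260 nM
- compound 2 `COc1cc(OC)cc([C@@H]2/C(=C\c3ccccc3)c3cc(OC)cc(OC)c3[C@H]2c2ccccc2)c1`: > 200000 nM

Compound 2 gives > 200000 nM in this assay, and this is a limit of the assay rather than a number. Compound 3 `COc1ccc(/C=C2/c3cc(OC)cc(OC)c3[C@@H](c3ccccc3)[C@@H]2c2cc(OC)cc(OC)c2)cc1` is compound 2 with a single structural change: methoxy in place of hydrogen on an aromatic carbon. A methoxy takes the place of hydrogen on an aromatic carbon, turning a phenyl into a 4-methoxyphenyl. Among the measured compounds shown here, no pair of measured compounds shows the size of this change directly, so any forecast is loose. Compound 1 does reach a true number in this assay, at 6260 nM, so a move towards stronger inhibition is expected, though its size is uncertain. The expected change is an at least 5.7-fold lower number from compound 2 to compound 3 (0.75 log units; beyond the scatter). The estimate for compound 3 is 35000 nM, with an expected range from 9000 nM to 200000 nM.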

Compound 3, half-maximal inhibitory concentration: > 200000 nM
Compound 3: no number, only a limit (the forecaster's own chance of this, stated with the estimate: 30%); middle value at least 5.7-fold (0.75 log units) from the limit.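

In this assay, a single 4-methoxyphenyl in place of a phenyl is not enough to give compound 3 a true number. Compound 2 and compound 3 both stand at a limit rather than a number, so the step between them cannot be read and the methoxy may still have some effect that stays hidden: the limit of > 200000 nM in this assay, at which 2 of the 3 values shown sit.

The new comparison lies elsewhere: compound 1 carries a further 4-methoxyphenyl where compound 3 has a phenyl, and hydrogen in place of that methoxy gives an at least 31-fold higher number from compound 1 to compound 3 (1.50 log units; beyond the scatter).

Among the compounds shown here, still open is whether this further methoxy would give a true number without the one that compound 3 already carries. Also open, on these data alone, is whether a hydroxyl, an amine or a longer ethoxy chain could stand in its place on that ring.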